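The source may hold more compounds than are shown below. What is called first, only, known or untested is meant among the compounds shown, and "the series" means these compounds.

Compound 1 `CCOC(=O)/C(=N\O)c1ccc(Sc2cc(F)cc(C3CCOCC3)c2)cc1`: 170 nM
Compound 2 `CC(=O)O/N=C(\C)c1ccc(Sc2cc(F)cc(C3CCOCC3)c2)cc1`: 50 nM
Compound 3 `CC(=O)/C(=N\O)c1ccc(Sc2cc(F)cc(C3CCOCC3)c2)cc1`: 850 nM

In a functional assay (blood) for inhibition, with Homo sapiens as the target (a higher number here means a weaker inhibitor, a lower number a stronger inhibitor), compound 3 gives the highest of the three numbers; the measured steps run a 5.0-fold higher number from compound 1 to compound 3 (0.70 log units; beyond the scatter) and a 17-fold higher number from compound 2 to compound 3 (1.23 log units; beyond the scatter). Compound 4 `C/C(=N\OCC#N)c1ccc(Sc2cc(F)cc(C3CCOCC3)c2)cc1` differs from compound 3 by a group of 7 heavy atoms (4 carbon, 2 nitrogen, 1 oxygen; no ring) in place of a group of 6 heavy atoms (3 carbon, 1 nitrogen, 2 oxygen; no ring), on an aromatic carbon; the group that enters carries no hydrogen-bond donor and the same number of acceptors. Going by the values given here, of the measured steps, the one from compound 2 bears most on this change, since compound 2 likewise carries a group without a donor at that aromatic carbon and sits far lower in this assay; the step from compound 1 is the smaller. A large fall is therefore expected, an 11-fold lower number from compound 3 to compound 4 (1.03 log units; beyond the scatter). Compound 4 is estimated at 80 nM, with a range from 30 nM to 250 nM.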

Compound 4, half-maximal inhibitory concentration: 20 nM
Compound 4: middle estimate off by 4.0-fold (0.60 log units), on the high side, outside the stated range (below it).
By their numbers in this assay, from the lowest: compound 4; then compound 2; then compound 1; then compound 3.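

In this assay, the group on the aromatic carbon para to a large group can be changed with a large gain, shown by a 43-fold lower number from compound 3 to compound 4 (1.63 log units; beyond the scatter), and the wider comparison gives an 8.5-fold lower number from compound 1 to compound 4 (0.93 log units; beyond the scatter). Cyanomethyl also improves on acetyl on the same oxygen, with a 2.5-fold lower number from compound 2 to compound 4 (0.40 log units; beyond the scatter), so this oxygen still has room for gains, and compound 4 has the lowest number of the four, with the two donor-free groups, in compound 2 and compound 4, ahead of compound 1 and compound 3. No measurement shown accounts for these differences. Open, from the compounds shown here alone, is whether the nitrile itself matters, since a plain methyl or ethyl on that oxygen would test this. Also open, going by these compounds, is how a longer chain, such as cyanoethyl, or a carboxylic acid there would fare.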